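Side-chain notes: from compound 2 to compound 3

The source may report more compounds than this note shows. Statements on the series, on what has been measured and on what is new or still open speak of the compounds shown alone.

- compound 1 `CC(C)c1n[nH]c2c(NCc3ccc(-c4ccccn4)cc3)nc(SCC(O)C(F)(F)F)nc12`: 690 nM
- compound 2 `CC(O)CSc1nc(NCc2ccc(-c3ccccn3)cc2)c2[nH]nc(C(C)C)c2n1`: 62 nM

Among the measured compounds shown here, in a functional assay on HT cells (Homo sapiens) for antiproliferative activity, read by fluorescence, with a stated time of 72 h (a higher number here means a weaker inhibitor of growth, a lower number a stronger inhibitor of growth), compound 2 gives 62 nM, the lower of the two numbers so far, while compound 1 gives 690 nM. Next in line is compound 3 `CC(C)c1n[nH]c2c(NCc3ccc(-c4ccccn4)cc3)nc(SCC(C)(C)O)nc12`, which keeps the shared core and differs from compound 2 only in the side chain: methyl in place of hydrogen on a saturated chain carbon bound to an oxygen on a saturated carbon and two saturated chain carbons. In words, (2-hydroxypropyl)sulfanyl becomes (2-hydroxy-2-methylpropyl)sulfanyl.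

For the measured compounds named here, only one measured step touches this part of the chain: an 11-fold lower number from compound 1 to compound 2 (1.05 log units; beyond the scatter). That step is large and beyond the scatter, but it exchanges trifluoromethyl for methyl, whereas the new change puts methyl in place of hydrogen. Going by the values given here, no measured pair shows the effect of that replacement, so the size of the earlier step does not carry over. No step beyond the scatter is expected in this assay, and no direction can be favoured, though this expectation rests on thin evidence. The estimated step is a 1.2-fold higher number from compound 2 to compound 3 (0.08 log units; within the scatter). For compound 3 the estimated value is 75 nM, with an expected range of 25 nM to 220 nM.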

Compound 3, concentration for 50% growth inhibition: 507 nM
Estimate against measurement, compound 3: 6.8-fold (0.83 log units) below, outside the stated range (above it).
By their numbers in this assay, from the lowest: compound 2; then compounds 3 and 1 (each within the scatter of the next).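

Notes on the carbon bearing the hydroxyl: in this assay, methyl in place of hydrogen on this saturated chain carbon gives an 8.2-fold higher number from compound 2 to compound 3 (0.91 log units; beyond the scatter), so this single added methyl, the first such replacement measured here, is enough to separate (2-hydroxy-2-methylpropyl)sulfanyl from (2-hydroxypropyl)sulfanyl. The comparison of the two chains that differ from that of compound 2 gives a 1.4-fold lower number from compound 1 to compound 3 (0.13 log units; within the scatter), which places 1-hydroxy-1-methylethyl and 2,2,2-trifluoro-1-hydroxyethyl on a level, with compound 2 alone at the low end among these three compounds. Nothing available on these compounds gives a reason for either step.

The three side chains all keep the hydroxyl on the same carbon, so they leave open whether the low number of compound 2 depends on that hydroxyl, as an amine or a methoxy group at that place would show. Also open, on these data alone, is how this carbon behaves with an ethyl group in place of the methyl of compound 2, or in a longer chain that carries the hydroxyl further out from the sulfur.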